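A few compounds are considered here, and "the series" means these few. Any claim that something is new, unique, unknown or untested is made for them only; others in the source may bear on it.

Measured compounds:
- compound 1 `O=C(NCc1ccco1)c1cc(S(=O)(=O)N2CCCCC2)cc(O)c1O`: 33000 nM
- compound 2 `O=C(NCC1CCCCC1)c1cc(S(=O)(=O)N2CCCCC2)cc(O)c1O`: > 40000 nM

Of the compounds shown here, two have been tested in an ADME assay on NCI-H630 cells (Homo sapiens) for cytotoxicity, read by MTT assay, with a stated time of 72 h; on this read-out higher numbers stand for lower toxicity in this test and lower numbers for higher toxicity in this test. Compound 1 `O=C(NCc1ccco1)c1cc(S(=O)(=O)N2CCCCC2)cc(O)c1O` gives 33000 nM in this assay. For compound 2 `O=C(NCC1CCCCC1)c1cc(S(=O)(=O)N2CCCCC2)cc(O)c1O` the assay reports only a limit, > 40000 nM, so its standing on the numbers is open. For the measured compounds named here, the single measured step, an at least 1.2-fold higher number from compound 1 to compound 2 (0.08 log units; that floor lies within the scatter), therefore rests on a limit, (the limit of > 40000 nM in this assay, at which 1 of the 2 values shown sits), and says little about direction.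

Compound 3 `O=C(NCc1cccs1)c1cc(S(=O)(=O)N2CCCCC2)cc(O)c1O` has not yet been tested. It differs from compound 2 in one place: thiophen-2-yl in place of cyclohexyl on a saturated chain carbon bound to an amide-type nitrogen. Going by the values given here, no measured step covers this exact change, but the thiophen-2-yl group of compound 3 is an aromatic five-membered ring with one hetero atom, as is the furan-2-yl group of compound 1, whose value is 33000 nM. Compound 3 is therefore expected to sit near compound 1 rather than at the limit, with an expected step of an at least 1.1-fold lower number from compound 2 to compound 3 (0.05 log units; that floor lies within the scatter) from the limit of compound 2. The estimate for compound 3 in this assay is 35000 nM, within a range of 15000 nM to 80000 nM, though a limit remains a real possibility.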

Compound 3, half-maximal cytotoxic concentration: > 40000 nM
Compound 3 gave a limit, no number (the forecaster's own chance of this, stated with the estimate: 40%); middle value at least 1.1-fold (0.05 log units) from the limit.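

In this assay compound 3 gives no number, only a limit of > 40000 nM, so the thiophen-2-yl group now stands at that limit together with the cyclohexyl group: the limit of > 40000 nM in this assay, at which 2 of the 3 values shown sit.

Against the furan-2-yl group, thiophen-2-yl on a saturated chain carbon bound to an amide-type nitrogen gives an at least 1.2-fold higher number from compound 1 to compound 3 (0.08 log units; that floor lies within the scatter), so the swap of one aromatic five-membered ring for the other is not yet told apart from the scatter, though the true size of the step may be larger than this floor. The step between compound 2 and compound 3 cannot be read, since both ends of it are limits. Compound 1 remains the only one of the three with an actual number, 33000 nM.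

On these data alone, what stays open is how far the true values of compound 2 and compound 3 lie past the limit, and so whether the saturated ring and the sulfur-bearing aromatic ring differ at all in this test. As far as these compounds go, it is also open whether an amine, a carboxylic acid or a longer chain at this place would give a number clearly lower than those seen here.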